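The compounds below may be only part of what the source reports. "The series", "measured", "known", "first", "only" and "open" are said of these compounds alone.

Measured in an ADME assay on HCT-116 cells (Homo sapiens) for cytotoxicity, read by CellTiter-Glo, with a stated time of 72 h; a higher number here means a weaker inhibitor, a lower number a stronger inhibitor:
Compound 1 `CC1CCN(C2CCN(S(=O)(=O)c3cccc(C(F)(F)F)c3)CC2)CC1`: > 5000 nM
Compound 2 `Cc1c(C)c(S(=O)(=O)N2CCC(N3CCC(C)CC3)CC2)c(C)c2c1OC(C)(C)C2`: > 10000 nM
Compound 3 `CC1CCN(C2CCN(S(=O)(=O)c3ccccc3Br)CC2)CC1`: > 5000 nM

Each of these entries is a limit of the assay and not a number. Compound 1 stands at the limit of > 5000 nM in this assay, at which 2 of the 3 values shown sit. Compound 2 stands at the limit of > 10000 nM in this assay, at which 1 of the 3 values shown sits.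

Compound 4 `COc1ccccc1-c1cccc(S(=O)(=O)N2CCC(N3CCC(C)CC3)CC2)c1` has not yet been measured. It keeps the core of compound 1 and changes one group: 2-methoxyphenyl in place of trifluoromethyl on an aromatic carbon. In words, 2-methoxyphenyl takes the place of trifluoromethyl on an aromatic carbon. Among the compounds with values here, no measured step between close relatives is available as a guide in this assay, so the expectation is loose, and no change beyond the scatter is expected. The estimated step that the limit leaves unreadable from compound 1 to compound 4 is therefore small, and another limit is quite possible. For compound 4 the estimate is 6000 nM, with an expected range from 2000 nM to 15000 nM.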

Compound 4, half-maximal inhibitory concentration: > 5000 nM
Compound 4: a limit, no number (the forecaster's own chance of this, stated with the estimate: 65%); the middle value does not contradict the limit.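

Within the data shown here, compound 1 and compound 4 are both recorded only as limits, not numbers, so no step between them can be read. The compounds shown leave open how strong any of them is as an inhibitor, and whether 2-methoxyphenyl in place of trifluoromethyl changes that at all.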